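A few compounds are considered here, and "the series" means these few. Any claim that something is new, unique, unknown or untested is made for them only; others in the source may bear on it.

Compound 2 `O=C(NCc1ccco1)c1ccc(CN2C(=O)c3ccccc3S2(=O)=O)cc1` was tested in a functional assay on RAW264.7 cells (Mus musculus) for inhibition (a higher number here means a weaker inhibitor, a lower number a stronger inhibitor), where compound 2 gives 24300 nM. Among the three compounds measured so far this is the second highest number. Its nearest neighbour is compound 1 `CC1=C(c2ccc(C)c(C)c2)S(=O)(=O)N(Cc2ccc(C(=O)N3CCCCC3)cc2)C1=O`, which in this assay gives 16500 nM; the two values lie within the scatter of each other. Furthest away is compound 3 `NC(=O)c1ccc(CN2C(=O)c3ccccc3S2(=O)=O)cc1`, which in this assay gives 50600 nM. Among the measured compounds shown here, the only step in the set that alters a single place is a 2.1-fold higher number from compound 2 to compound 3 (0.32 log units; beyond the scatter), hydrogen in place of (furan-2-yl)methyl on an amide-type nitrogen.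

Compound 4 `CC(C)(C)OC(=O)N(Cc1ccco1)C(=O)c1ccc(CN2C(=O)c3ccccc3S2(=O)=O)cc1` has not yet been measured. It differs from compound 2 in one place: tert-butoxycarbonyl in place of hydrogen on an amide-type nitrogen. For the measured compounds named here, no measured pair shows tert-butoxycarbonyl entering at this nitrogen, so the bearing step is only a 2.1-fold higher number from compound 2 to compound 3 (0.32 log units; beyond the scatter), which shows that what sits on this amide-type nitrogen shifts the number modestly, there toward a higher value. A step of similar or smaller size is therefore expected for compound 4, leaning toward a higher number, though a result within the scatter would not surprise. The step from compound 2 to compound 4 is estimated at a 1.2-fold higher number from compound 2 to compound 4 (0.09 log units; within the scatter). Compound 4 is expected to give about 30000 nM in this assay, within a range of 12000 nM to 75000 nM.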

Compound 4, half-maximal inhibitory concentration: 2610 nM
Compound 4: middle estimate off by 11-fold (1.06 log units), on the high side; the measured number lies below the stated range.
By their numbers in this assay, from the lowest: compound 4; then compounds 1 and 2 (each within the scatter of the next); then compound 3.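

In this assay, among the compounds shown here, the amide-type nitrogen proves able to carry much more than the earlier compounds showed, and tert-butoxycarbonyl in place of hydrogen there gives a 9.3-fold lower number from compound 2 to compound 4 (0.97 log units; beyond the scatter). This step runs opposite to a 2.1-fold higher number from compound 2 to compound 3 (0.32 log units; beyond the scatter) and is larger, so of the two steps that start from compound 2, the number rises where a group is taken off this nitrogen and falls where one is added. Compound 4 also has no amide hydrogen left, which shows that this hydrogen is not required for a lower number than that of compound 2, although nothing available explains the size or direction of the step.

As far as these compounds go, what remains open is whether the drop belongs to tert-butoxycarbonyl in particular or would also appear with another group on this nitrogen, such as acetyl, methyl or benzyloxycarbonyl. From the compounds shown here alone, it is also open whether tert-butoxycarbonyl would give a step of similar size without the (furan-2-yl)methyl group on the same nitrogen, or with a longer chain in its place.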